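Aminoquinolinol amides: diethylamino to isopropyl on the aryl

The source may hold more compounds than are shown below. What is called first, only, known or untested is meant among the compounds shown, and "the series" means these compounds.

Measured compounds in the series:
compound 1, `CCCC(=O)NC(c1ccc(N(CC)CC)cc1)c1cc(Cl)c2cccnc2c1O`, 100 nM
compound 2, `CCCCOc1ccnc2c(O)c(CNC(=O)C3CCCCC3)ccc12`, 510 nM
compound 3, `CCCCC(=O)NC(c1cc(Cl)cc(Cl)c1)c1ccc2cccnc2c1O`, 140 nM

All three were tested in a functional assay on Daoy cells (Homo sapiens) for antiproliferative activity, read by trypan blue exclusion and crystal violet staining, with a stated time of 72 h; on this read-out lower numbers stand for stronger inhibition and higher numbers for weaker inhibition. Compound 1 gives the lowest number of the three, at 100 nM. Compound 3 sits nearest, with 140 nM, a gap that lies within the usual scatter, so no order between compound 1 and compound 3 can be claimed. Compound 2, at 510 nM, stands furthest from compound 1, and that gap lies beyond the scatter.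

The next compound, compound 4, `CCCC(=O)NC(c1ccc(C(C)C)cc1)c1cc(Cl)c2cccnc2c1O`, has not been measured. It differs from compound 1 in one place: isopropyl in place of diethylamino on an aromatic carbon. Compound 3 shows that a differently substituted aryl group still gives a low number, so the change is expected to produce, at most, a small step in this assay, with no step beyond the scatter expected; if anything, the number is expected to move slightly upward. For compound 4 the estimated value is 150 nM, with an expected range from 50 nM to 450 nM, which corresponds to an expected step of a 1.5-fold higher number from compound 1 to compound 4 (0.18 log units; within the scatter).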

Compound 4, half-maximal inhibitory concentration: 90 nM
For compound 4 the middle estimate is 1.7-fold (0.22 log units) above the measured one; the range from low to high includes it.
By their numbers in this assay, from the lowest: compounds 4, 1 and 3 (each within the scatter of the next); then compound 2.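

In this assay, isopropyl in place of diethylamino on an aromatic carbon, para to a large group, gives a 1.1-fold lower number from compound 1 to compound 4 (0.05 log units; within the scatter), so no order between the two compounds can be claimed. Among the compounds shown here, this is the first one-place comparison: at this position, the nitrogen and the hydrogen-bond acceptor counted for diethylamino are not required to keep the number at this level, and an all-carbon group with fewer heavy atoms serves equally well in this read-out. No measurement is available that would explain this flat step.

The compounds shown leave open whether a carboxylic acid, a primary amine or a longer alkyl chain on this aromatic carbon would hold the number at this level. They also leave open how a bare hydrogen at this position would compare.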